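Methoxy in Place of Methyl on a Benzyl Ring

The compounds below may be only part of what the source reports. "The series", "measured", "known", "first", "only" and "open" are said of these compounds alone.

Measured compounds:
compound 1 `COc1ccc(Cn2c(=O)nc(NCCNC(=N)N)n(Cc3ccc(Cl)c(Cl)c3)c2=O)cc1`, 0.0045 nM
compound 2 `Cc1ccc(Cn2c(NCCNC(=N)N)nc(=O)n(Cc3ccc(C(F)(F)F)cc3)c2=O)cc1`, 0.000033 nM
compound 3 `Cc1ccc(Cn2c(=O)nc(NCCNC(=N)N)n(Cc3ccc(Cl)c(Cl)c3)c2=O)cc1`, 0.0051 nM

In a functional assay on the whole organism (strain C57Bl/6) for inhibition, with Mus musculus as the target, with a stated time of 180 min, at 48 degrees C (a higher number here means that more compound is needed for the effect, a lower number that less compound is needed), compound 2 stands lowest of the three, far below compound 1 and compound 3. The difference between the core of compound 2 and that of compound 3 is not broken down here. Compound 1 and compound 3 differ in one place, (methoxy in place of methyl on an aromatic carbon), and that change gave a 1.1-fold lower number from compound 3 to compound 1 (0.05 log units; within the scatter).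

Compound 4 `COc1ccc(Cn2c(NCCNC(=N)N)nc(=O)n(Cc3ccc(C(F)(F)F)cc3)c2=O)cc1`, not yet measured, carries the same change on compound 2: methoxy in place of methyl on an aromatic carbon. The step is expected to be a 1.1-fold lower number from compound 2 to compound 4 (0.04 log units; within the scatter), set beside a 1.1-fold lower number from compound 3 to compound 1 (0.05 log units; within the scatter), because the same change between compound 3 and compound 1 gave a 1.1-fold lower number from compound 3 to compound 1 (0.05 log units; within the scatter) and the place of the change is the same. In this assay compound 4 is therefore estimated at 0.00003 nM, likely between 0.00001 nM and 0.0001 nM.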

Compound 4, half-maximal effective concentration: 0.051 nM
The estimate for compound 4 lay 1700-fold (3.23 log units) below the measured number; measured number above the stated range.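

Methoxy in place of methyl did not carry from one core to the other in this series, and the two steps in this assay stand clearly apart: the same change on two cores in this assay, a 1.1-fold lower number (0.05 log units; within the scatter) from compound 3 to compound 1 and a 1500-fold higher number (3.19 log units; beyond the scatter) from compound 2 to compound 4, 1800-fold (3.24 log units) apart, beyond the scatter of two such steps

On the second core the change gave a 1500-fold higher number from compound 2 to compound 4 (3.19 log units; beyond the scatter), although it had made no difference beyond the scatter on the first. Among these compounds, this shows that the size of the step depends on the core, but it does not show which part of the core is responsible, as the cores differ in more than one place and each offers only a single pair.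

On these data alone, whether an amine or a hydroxyl group in the same place would behave like methoxy on either core remains open. So does whether the large step would persist with a nitrile in place of trifluoromethyl.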